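Trading an Amide Side Chain for a Phenyl Ether

This account rests on a few compounds, and the source may have more. Where it says the series, first, only, none or still open, it means among the compounds named here.

In an assay on isolated protein (strain Sprague-Dawley) for inhibition of Amine oxidase [flavin-containing] B (Rattus norvegicus), read by spectrophotometry, with a stated time of 5 min (on this read-out higher numbers stand for weaker inhibition and lower numbers for stronger inhibition), compound 3 `CNC(=O)COc1cc(=O)oc2cc(OCc3cccc(Cl)c3)ccc12` gives 33.9 nM, the lower of the two single numbers shown; compound 1 `CCOC(=O)COc1cc(=O)oc2cc(OCc3cccc(Cl)c3)ccc12` gives 1820 nM, and compound 2 `NC(=O)COc1cc(=O)oc2cc(OCc3cccc(Cl)c3)ccc12` gives 3.1 nM; 3.31 nM (2 entries) across its repeated entries (the several entries of compound 2 in this assay, 3.1 nM; 3.31 nM (2 entries)). Compound 4 `O=c1cc(Oc2ccccc2)c2ccc(OCc3cccc(Cl)c3)cc2o1` has not yet been measured; it differs from compound 3 by phenyl in place of (methylcarbamoyl)methyl on an oxygen on an aromatic ring. Among the compounds with values here, the only measured step at this position, a 54-fold lower number from compound 1 to compound 3 (1.73 log units; beyond the scatter), shows that what hangs on this oxygen can shift the number a long way. Replacing the whole amide chain by a phenyl removes the very groups that separate compounds 1, 2 and 3, so the direction is uncertain; a weakening is expected, a 5.9-fold higher number from compound 3 to compound 4 (0.77 log units; beyond the scatter). Compound 4 is therefore estimated at 200 nM, within 20 nM to 2000 nM.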

Compound 4, half-maximal inhibitory concentration: 4070 nM
Compound 4: middle estimate off by 20-fold (1.31 log units), on the low side; measured number above the stated range.
By their numbers in this assay, from the lowest: compound 3; then compound 1; then compound 4.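

Phenyl on this oxygen is no substitute for the amide chain: the change brings a 120-fold higher number from compound 3 to compound 4 (2.08 log units; beyond the scatter) and so cancels all that the methylamide had gained over the ester. The phenyl also falls modestly short of the ester chain itself, with a 2.2-fold higher number from compound 1 to compound 4 (0.35 log units; beyond the scatter) on the same read-out.

Going by these compounds, whether a carboxylic acid chain, a longer amide chain or a benzyl group on this oxygen would do better than phenyl stays open. The data shown offer no explanation for the size of this loss.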